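This account rests on a few compounds, and the source may have more. Where it says the series, first, only, none or still open, it means among the compounds named here.

Of the compounds shown here, three sharing one core have been tested in an ADME assay on HFF cells (Homo sapiens) for cytotoxicity, read by MTT assay, with a stated time of 72 h; on this read-out lower numbers stand for stronger inhibition and higher numbers for weaker inhibition. Compound 1 `O=C1O/C(=C\Cn2cc(-c3cc(C(F)(F)F)cc(C(F)(F)F)c3)nn2)C(OCc2ccccc2)=C1OCc1ccccc1` gives > 100000 nM, which is a limit of the assay and not a number. Compound 3 `O=C1O/C(=C\Cn2cc(-c3cccc(O)c3)nn2)C(OCc2ccccc2)=C1OCc1ccccc1` gives 42600 nM. Compound 2 `O=C1O[C@H]([C@@H](O)Cn2cc(CNS(=O)(=O)c3ccc(F)cc3)nn2)C(OCc2ccccc2)=C1OCc1ccccc1` gives 30 nM, the lower of the two true numbers, and the gap to compound 3 lies far beyond the scatter.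

Compound 4 `C[Si](C)(C)c1cn(C[C@H](O)[C@H]2OC(=O)C(OCc3ccccc3)=C2OCc2ccccc2)nn1` has not yet been measured. It departs from compound 2 at a single place: a group of 4 heavy atoms (3 carbon, 1 silicon; no ring) in place of a group of 12 heavy atoms (7 carbon, 1 nitrogen, 2 oxygen, 1 fluorine, 1 sulfur; one six-membered aromatic ring of carbon only), on an aromatic carbon. The (((4-fluorophenyl)sulfonyl)amino)methyl group is therefore lost, and a much smaller group takes its place.

Only one of the three tested compounds reaches a number this low, so a large change at this place seems more likely to raise the number than to preserve it. The expected step of a 270-fold higher number from compound 2 to compound 4 (2.43 log units; beyond the scatter) is a large rise, beyond the scatter, towards weaker inhibition. For compound 4 the estimated value is 8000 nM, with an expected range from 500 nM to 80000 nM.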

Compound 4, half-maximal inhibitory concentration: 20000 nM
Beside the measured number, compound 4's estimate is 2.5-fold (0.40 log units) below it, within the range that was stated.
By their numbers in this assay, from the lowest: compound 2; then compound 4; then compound 3. At a limit, above all of these: compound 1.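

In this assay, replacing the (((4-fluorophenyl)sulfonyl)amino)methyl group on this aromatic carbon with the small silicon-bearing group gives a 670-fold higher number from compound 2 to compound 4 (2.82 log units; beyond the scatter). The earlier compounds shown here differed from one another in more than one place, whereas this pair differs at this position alone, which ties the low number of compound 2 to the group held here. Compound 4 still gives a true number rather than a limit, and only compound 1 sits at a limit of the assay: the limit of > 100000 nM in this assay, at which 1 of the 4 values shown sits.

Only one replacement at this position is shown, and it removes the sulfonyl, the amide-type nitrogen and the fluorinated ring all at once, leaving open which of these parts matters. A simple aminomethyl group or a phenyl ring at the same carbon would begin to separate them.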